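The compounds below may be only part of what the source reports. "The series", "measured", "known", "first", "only" and "open" are said of these compounds alone.

Among the measured compounds shown here, compound 1 `COc1c(/C=C2/C(=O)Nc3ccccc32)c2ccccc2n1-c1ccccc1` is one of two compounds measured in a functional assay on cells (Cancer cell lines, Homo sapiens) for cytotoxicity, with a stated time of 48 h; on this read-out lower numbers stand for stronger inhibition of growth and higher numbers for weaker inhibition of growth. In this assay compound 1 gives 8510 nM, the lower of the two numbers. Compound 2 `COc1ccc2c(c1)/C(=C\c1c(Cl)n(Cc3cc(OC)c(OC)c(OC)c3)c3cc(C)c(OC)cc13)C(=O)N2` gives 75900 nM, a higher number, and the gap between the two lies beyond the usual scatter, so compound 1 inhibits growth more strongly than compound 2. Compound 3 `COc1c(/C=C2/C(=O)Nc3ccc(Cl)cc32)c2ccccc2n1-c1ccccc1` has not yet been measured in this assay. It differs from compound 1 in one place: chloro in place of hydrogen on an aromatic carbon. For the measured compounds named here, no pair of measured compounds here shows a step of this kind, so the expectation rests on compound 1 alone. With nothing measured to draw on, the step of a 1.4-fold lower number from compound 1 to compound 3 (0.15 log units; within the scatter) is expected to be modest, in either direction, and most likely not beyond the scatter. For compound 3 the estimated value in this assay is 6000 nM, with a range from 2000 nM to 20000 nM.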

Compound 3, concentration for total growth inhibition: 19100 nM
For compound 3 the middle estimate is 3.2-fold (0.50 log units) below the measured one; low and high end bracket the measured number.
By their numbers in this assay, from the lowest: compound 1; then compound 3; then compound 2.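

Read in this assay the exchange of hydrogen for chloro on this aromatic carbon gives a 2.2-fold higher number from compound 1 to compound 3 (0.35 log units; beyond the scatter) and so marks a loss of growth inhibition. This position of the shared core is therefore not indifferent to substitution: one added chlorine atom is enough to move the result past the usual scatter, though the step stays modest in size. Nothing measured here explains why this exchange weakens growth inhibition.

Going by these compounds, whether the loss belongs to chloro alone or to any group at this carbon stays open, as a fluoro or an amino group here would be needed to tell the two apart. On these data alone, it is also open whether chloro on another carbon of the same ring would give a similar step.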